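A few compounds are considered here, and "the series" means these few. Any claim that something is new, unique, unknown or untested is made for them only; others in the source may bear on it.

Working notes on a small set of compounds tested in a functional assay on K562 cells (Homo sapiens), read by MTT assay, with a stated time of 72 h; on this read-out lower numbers stand for stronger inhibition and higher numbers for weaker inhibition. Compound 1 `O=c1[nH]cnc2c1c(-c1ccco1)cn2[C@@H]1O[C@H](CO)[C@@H](O)[C@H]1O` carries a furan-2-yl group on the shared core; in this assay compound 1 gives 17800 nM. Compound 2 `O=c1[nH]cnc2c1c(-c1cc3ccccc3o1)cn2[C@@H]1O[C@H](CO)[C@@H](O)[C@H]1O` carries a 1-benzofuran-2-yl group at the same place. In this assay compound 2 reaches only the limit > 20000 nM. The change between the two is furan-2-yl in place of 1-benzofuran-2-yl on an aromatic carbon, and the step recorded for it is an at least 1.1-fold lower number from compound 2 to compound 1 (0.05 log units; that floor lies within the scatter), so the pair sits close together. Compound 3 `Nc1nc(N)c2c(-c3cc4ccccc4o3)cn([C@@H]3O[C@H](CO)[C@@H](O)[C@H]3O)c2n1` has a different core from compound 2; the difference between the two cores is not broken down here. In this assay compound 3 likewise reaches only the limit > 20000 nM. Of the three values shown, two sit at the limit of > 20000 nM in this assay, at which 2 of the 3 values shown sit.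

Compound 4 `Nc1nc(N)c2c(-c3ccco3)cn([C@@H]3O[C@H](CO)[C@@H](O)[C@H]3O)c2n1` is not yet measured. From compound 3 to compound 4 the change is furan-2-yl in place of 1-benzofuran-2-yl on an aromatic carbon, the same kind of change as from compound 2 to compound 1, and the place of the change is the same in both pairs. The earlier step of an at least 1.1-fold lower number from compound 2 to compound 1 (0.05 log units; that floor lies within the scatter) lies within the scatter. On that basis the expected step is a number no higher from compound 3 to compound 4 (the limit leaves the size open), small and uncertain in direction. Compound 4 is therefore estimated at 20000 nM, with a range from 11000 nM to 40000 nM, and with a fair chance that this assay again reports only a limit for compound 4.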

Compound 4, half-maximal inhibitory concentration: > 20000 nM
Compound 4 ended at the assay's limit (the forecaster's own chance of this, stated with the estimate: 55%); the middle value sits exactly at the limit.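

Among the compounds shown here, compound 3 and compound 4 both stop at a limit in this assay, so no step between them can be read, and the furan-2-yl for 1-benzofuran-2-yl change yields no size on this core: the limit of > 20000 nM in this assay, at which 3 of the 4 values shown sit. The compounds shown leave open whether that change shifts the number at all on the core of compound 3, and how compound 2, compound 3 and compound 4 stand relative to one another beyond the limit.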